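Oxazolyl in Place of Methanesulfonamido: an Expected Loss

The source may hold more compounds than are shown below. What is called first, only, known or untested is meant among the compounds shown, and "the series" means these compounds.

Compound 1 `Cn1ccc(-c2cccc3c2CCC3c2ncc[nH]2)n1` gives in a functional assay on CHO cells for agonist activity at Alpha-1A adrenergic receptor (Homo sapiens), read by FLIPR and calcium flux (a higher number here means that more compound is needed for the effect, a lower number that less compound is needed), only a limit, > 1300 nM.
Compound 2 `COc1cccc2c1CCC2c1ncc[nH]1` gives in this assay 32 nM.
Compound 3 `CS(=O)(=O)Nc1cccc2c1CCC2c1ncc[nH]1` gives in this assay 70 nM.

Among the two numbers shown, compound 3 holds the higher one; the nearest is compound 2, and the change from methoxy to methanesulfonamido gave a 2.2-fold higher number from compound 2 to compound 3 (0.34 log units; beyond the scatter). Compound 1 sits at the limit of the limit of > 1300 nM in this assay, at which 1 of the 3 values shown sits, so its steps to the others are only bounds.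

Compound 4 `c1cc(-c2ncco2)c2c(c1)C(c1ncc[nH]1)CC2` differs from compound 3 in one place: 1,3-oxazol-2-yl in place of methanesulfonamido on an aromatic carbon. Among the compounds with values here, the step that bears most on this is the one between compound 1 and compound 3, where a five-membered heteroaromatic ring at the same carbon was replaced by methanesulfonamido and gave an at least 18-fold lower number from compound 1 to compound 3 (1.26 log units; beyond the scatter); likewise an at least 40-fold lower number from compound 1 to compound 2 (1.60 log units; beyond the scatter) for methoxy. Compound 4 returns a five-membered heteroaromatic ring to that carbon, though a different one, so the account expects the number to move back up, estimated as an 8.6-fold higher number from compound 3 to compound 4 (0.93 log units; beyond the scatter). Compound 4 is therefore estimated at 600 nM, with a range of 150 nM to 2500 nM, and a real chance that, like compound 1, only a limit is reported.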

Compound 4, half-maximal effective concentration: 170 nM
Compound 4: the middle estimate sits 3.5-fold (0.55 log units) above what was measured, and the stated range covers the measured number.
By their numbers in this assay, from the lowest: compound 2; then compound 3; then compound 4. At a limit, above all of these: compound 1.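

In this assay, compound 4 shows that a five-membered aromatic ring at this carbon does not by itself lose the effect, since the identity of the ring matters: the change from 1-methyl-1H-pyrazol-3-yl to 1,3-oxazol-2-yl gives an at least 7.6-fold lower number from compound 1 to compound 4 (0.88 log units; beyond the scatter). Compound 1 carries a limit and not a number, so that step is a bound only: the limit of > 1300 nM in this assay, at which 1 of the 4 values shown sits. The ring still costs something against the two non-ring groups, though the cost is modest, with a 2.4-fold higher number from compound 3 to compound 4 (0.39 log units; beyond the scatter) and a 5.3-fold higher number from compound 2 to compound 4 (0.73 log units; beyond the scatter), so methoxy and methanesulfonamido both keep the lower numbers at this carbon.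

What the compounds shown leave open is which difference between the two rings separates compound 1 from compound 4, the methyl group or the ring atoms, and an unsubstituted 1H-pyrazol-3-yl or a methyl-bearing 1,3-oxazol-2-yl would bear on that. Also open, as far as these compounds go, is how simpler groups at the same carbon, such as an amine, a carboxylic acid or a longer alkoxy chain, would compare with methoxy.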